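This account rests on a few compounds, and the source may have more. Where it says the series, first, only, none or still open, it means among the compounds named here.

Compound 1 `COc1ccc(/C=N/Nc2nc3ccccc3nc2Cc2ccccc2)cc1` — 63 nM
Compound 2 `CN(C)c1ccc(/C=N/Nc2nc3ccccc3nc2Cc2ccccc2)cc1` — 83 nM

Of the compounds shown here, two have been measured so far in an assay on isolated protein for inhibition of Amine oxidase [flavin-containing] A (Homo sapiens), read by spectrophotometry (on this read-out lower numbers stand for stronger inhibition and higher numbers for weaker inhibition), and compound 2 gives 83 nM, the higher of the two numbers; its only neighbour is compound 1, which gives 63 nM. Among the measured compounds shown here, the single step between them, a 1.3-fold higher number from compound 1 to compound 2 (0.12 log units; within the scatter), does not exceed the scatter. Compound 3 `O=[N+]([O-])c1ccc(/C=N/Nc2nc3ccccc3nc2Cc2ccccc2)cc1` differs from compound 2 in one place: nitro in place of dimethylamino on an aromatic carbon. For the measured compounds named here, the only measured step that bears on this change is the one from compound 1 to compound 2, where exchanging one group on the same aromatic carbon left the number essentially unchanged. On that basis the step of a 1.2-fold higher number from compound 2 to compound 3 (0.08 log units; within the scatter) is expected to stay within the scatter, with no clear direction. Compound 3 is therefore estimated at 100 nM, in a range from 25 nM to 400 nM.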

Compound 3, half-maximal inhibitory concentration: 8.8 nM
Compound 3: the middle estimate sits 11-fold (1.06 log units) above what was measured; measured number below the stated range.
By their numbers in this assay, from the lowest: compound 3; then compounds 1 and 2 (each within the scatter of the next).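

Nitro in place of dimethylamino gives a 9.4-fold lower number from compound 2 to compound 3 (0.97 log units; beyond the scatter) and nitro in place of methoxy gives a 7.2-fold lower number from compound 1 to compound 3 (0.85 log units; beyond the scatter) in this assay on the same aromatic carbon. The swap between the two earlier groups suggested that this place on the ring, para to a large group, hardly mattered, but these steps show that the number can shift well beyond the scatter when the group there changes. Compound 3 now stands apart from compound 1 and compound 2, which stay within the scatter of each other, and no measurement is at hand to say what lies behind this. As far as these compounds go, whether the stronger inhibition is particular to nitro remains open. A nitrile, a trifluoromethyl or a carboxylic acid on the same carbon would test this, as would nitro on another carbon of the ring.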